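The source may report more compounds than this note shows. Statements on the series, on what has been measured and on what is new or still open speak of the compounds shown alone.

Measured compounds:
- compound 1, `CC(C)NNc1nnc(-c2ccccc2Cl)s1`: 50 mg/kg
- compound 2, `Clc1ccccc1-c1nnc(NNC2CCCC2)s1`: > 100 mg/kg
- compound 3, `Cc1ccccc1-c1nnc(N(C)NC(C)C)s1`: 35 mg/kg

The three compounds were tested in a functional assay on the whole organism with Mus musculus as the target, in the maximal electroshock model, with a stated time of 1 h; on this read-out lower numbers stand for an effect already at smaller amounts and higher numbers for an effect only at larger amounts of compound. Compound 1 gives 50 mg/kg in this assay. Compound 3 gives 35 mg/kg in this assay, and the two numbers lie within the scatter of each other, so nothing separates them. For compound 2 the assay reports only a limit, > 100 mg/kg, and not a number.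

Compound 1 and compound 2 share a core and differ in one place: cyclopentyl in place of isopropyl on an amine nitrogen. The step is an at least 2.0-fold higher number from compound 1 to compound 2 (0.30 log units; that floor lies within the scatter); it rests on (the limit of > 100 mg/kg in this assay, at which 1 of the 3 values shown sits), so its true size is not known, only that it reaches that floor. Compound 1 and compound 3 differ in more than one place, and the difference between their two cores is not broken down here.

Compound 4, `Cc1ccccc1-c1nnc(N(C)NC2CCCC2)s1`, has not yet been measured. It stands to compound 3 as compound 2 stands to compound 1: cyclopentyl in place of isopropyl on an amine nitrogen. The place of the change is the same in both pairs, so this is the same change on a different core. The expectation for compound 4 therefore leans on the step from compound 1 to compound 2, which raised the number to the limit of the assay. Compound 4 is expected to give 80 mg/kg in this assay. The expected step is a 2.3-fold higher number from compound 3 to compound 4 (0.36 log units; beyond the scatter). The number for compound 4 is expected to fall between 45 mg/kg and 160 mg/kg.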

Compound 4, dose for half-maximal effect: 110 mg/kg
For compound 4 the middle estimate is 1.4-fold (0.14 log units) below the measured one, and the stated range covers the measured number.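

On the core of compound 3, cyclopentyl in place of isopropyl on an amine nitrogen gives, in this assay, a 3.1-fold higher number from compound 3 to compound 4 (0.50 log units; beyond the scatter), so compound 4 needs a larger dose for the same effect. For compound 2 the assay gives only a limit, > 100 mg/kg, and not a number. The change therefore raises the number on the core of compound 3 by a step beyond the scatter and is compatible with a rise on the core of compound 1, but this does not show that its size carries over from one core to the other or that it would hold on a further core: the same change on two cores in this assay, an at least 2.0-fold higher number (0.30 log units; that floor lies within the scatter) from compound 1 to compound 2 and a 3.1-fold higher number (0.50 log units; beyond the scatter) from compound 3 to compound 4; the limit leaves it open whether they differ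

The compounds shown leave open how a smaller group such as methyl, a ring of another size such as cyclohexyl, or a group bearing a hydroxyl would behave in the place of isopropyl on this amine nitrogen. They also leave open how much each of the differences between the core of compound 1 and the core of compound 3 contributes on its own.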